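Methoxy for methyl on the shared core: solubility note

The source may report more compounds than this note shows. Statements on the series, on what has been measured and on what is new or still open speak of the compounds shown alone.

The series shares a core in which a nitroimidazole-bearing hydroxypropyl chain is joined to a quinolone acid. Compound 1 `Cc1ncc([N+](=O)[O-])n1CC(O)Cn1cc(C(=O)O)c(=O)c2ccc(C(F)(F)F)cc21` carries a trifluoromethyl on the carbocyclic ring; in a physicochemical assay for solubility, read by spectrophotometry (a higher number here means a more soluble compound, a lower number a less soluble compound), compound 1 gives 790 ug/mL. Compound 2 `Cc1ccc2c(c1)c(=O)c(C(=O)O)cn2CC(O)Cn1c([N+](=O)[O-])cnc1C` carries a methyl there instead; in this assay compound 2 gives 390 ug/mL, the lower of the two numbers, and the gap to compound 1 lies beyond the usual scatter. Among the compounds with values here, the two compounds differ in more than one place, so no single step between them is counted.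

Compound 3 `COc1ccc2c(c1)c(=O)c(C(=O)O)cn2CC(O)Cn1c([N+](=O)[O-])cnc1C` is the next point. It differs from compound 2 in one place: methoxy in place of methyl on an aromatic carbon. Within the data shown here, no measured pair shows this exchange on this core, so the step can only be judged as an expectation: a shift of modest size, if any, from compound 2 to compound 3 of a 1.2-fold higher number from compound 2 to compound 3 (0.06 log units; within the scatter), not clearly beyond the scatter. Compound 3 is accordingly expected to give about 450 ug/mL in this assay, with a likely range from 200 ug/mL to 1000 ug/mL.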

Compound 3, solubility: 400 ug/mL
Estimate against measurement, compound 3: 1.1-fold (0.05 log units) above, and the stated range covers the measured number.
By their numbers in this assay, from the lowest: compounds 2, 3 and 1 (each within the scatter of the next, the first and the last beyond it).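

Methoxy in place of methyl on an aromatic carbon, meta to a fused ring and para to a fused ring, gives a 1.0-fold higher number from compound 2 to compound 3 (0.01 log units; within the scatter) in this assay and leaves the read-out on the shared core unmoved at this position. Within the data shown here, this is the first single-place step, since compound 1 and compound 2 differ in more than one place and could not speak to any one position; here the added oxygen and hydrogen-bond acceptor come with no separation beyond the scatter. No measurement at hand offers an explanation for this flat step.

From the compounds shown here alone, whether an amine, a carboxylic acid or a longer chain at this aromatic carbon would behave the same way remains open. The number for compound 1 also cannot yet be assigned to its trifluoromethyl, as that compound differs from compound 2 in more than one place.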